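The compounds below may be only part of what the source reports. "The series", "measured", "known", "first", "only" and "open" are said of these compounds alone.

Three compounds have been measured in an assay on CHO-K1 cells for displacement of a labelled ligand from melanin-concentrating hormone receptor 1 (Homo sapiens), read by scintillation proximity assay, with a stated time of 2 h; a higher number here means a weaker inhibitor, a lower number a stronger inhibitor:

Compound 1 `COCCC1(O)CCN(c2nc(C)c3cc(NC(=O)/C=C/c4ccc(Cl)cc4)ccc3n2)CC1` gives 245 nM.
Compound 2 `Cc1nc(N2CCC(N3CCOC3=O)CC2)nc2ccc(NC(=O)/C=C/c3ccc(OC(F)(F)F)cc3)cc12` gives 41 nM.
Compound 3 `Cc1nc(N2CCC(O)(C3CCC3)CC2)nc2ccc(NC(=O)/C=C/c3ccc(Cl)cc3)cc12` gives 206 nM.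

Among these, compound 2 stands at the lowest number, and its gaps to compound 3 and to compound 1 both lie beyond the usual scatter, so on these numbers compound 2 is the strongest binder of the three. Compound 1 and compound 3, in turn, sit close together: a 1.2-fold lower number from compound 1 to compound 3 (0.08 log units; within the scatter).

Compound 4 `Cc1nc(N2CCC(N3CCCC3=O)CC2)nc2ccc(NC(=O)/C=C/c3ccc(OC(F)(F)F)cc3)cc12` differs from compound 2 in one place: 2-oxopyrrolidin-1-yl in place of 2-oxo-1,3-oxazolidin-3-yl on a saturated ring carbon.

Among the measured compounds shown here, only one measured step touches the same saturated ring carbon, the one from compound 1 to compound 3, and it stayed within the scatter; it exchanges different groups, though, so it gives no direct guide to the present swap. For the measured compounds named here, no measured pair shows how the group that enters compares with the group that leaves. The step of a 1.2-fold higher number from compound 2 to compound 4 (0.09 log units; within the scatter) is therefore expected to be small, with no direction claimed beyond the scatter. Compound 4 is estimated at 50 nM, in the range 20 nM to 130 nM.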

Compound 4, half-maximal inhibitory concentration: 11 nM
Estimate against measurement, compound 4: 4.5-fold (0.66 log units) above, and the stated range ends above it.
By their numbers in this assay, from the lowest: compound 4; then compound 2; then compounds 3 and 1 (each within the scatter of the next).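

At the saturated ring carbon three ring bonds from the ring nitrogen, the step in this assay from 2-oxo-1,3-oxazolidin-3-yl to 2-oxopyrrolidin-1-yl goes beyond the scatter, a 3.7-fold lower number from compound 2 to compound 4 (0.57 log units; beyond the scatter), which the earlier step at such a carbon did not. The two groups have the same count of heavy atoms and each is a five-membered non-aromatic ring, yet one oxygen in the group that leaves is a carbon in the group that enters, so this place responds to a change of a single ring atom. Nothing measured here explains why the number moves in this direction.

The compounds shown leave open how a 2-oxopiperidin-1-yl group or an open-chain acetamide would read on this carbon. They also leave open whether the same exchange gives a step of similar size when the trifluoromethoxy group of compound 2 and compound 4 is replaced by a chlorine.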